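A few compounds are considered here, and "the series" means these few. Any claim that something is new, unique, unknown or untested is made for them only; others in the source may bear on it.

Measured so far:
Compound 1, `COc1cc(/C=C2\Cc3ccccc3/C(=C\c3ccc([N+](=O)[O-])cc3)C2=O)ccc1O`: in a functional assay on HL-60 cells (Homo sapiens) for cytotoxicity (on this read-out lower numbers stand for higher toxicity in this test and higher numbers for lower toxicity in this test), compound 1 gives 950 nM.
Compound 2, `COc1ccc(/C=C2\Cc3ccccc3/C(=C\c3ccc([N+](=O)[O-])cc3)C2=O)cc1`: in this assay compound 2 gives 4400 nM.

Among the measured compounds shown here, compound 2 stands at the highest of the two numbers; the only measured step onto it is a 4.6-fold higher number from compound 1 to compound 2 (0.67 log units; beyond the scatter). Compound 3, `COc1ccc(/C=C2\Cc3ccccc3/C(=C\c3ccc([N+](=O)[O-])cc3)C2=O)cc1OC`, differs from compound 2 in one place: methoxy in place of hydrogen on an aromatic carbon. For the measured compounds named here, no measured step matches this change exactly. The step from compound 1 to compound 2 touches the same ring, but it exchanges the whole group, 4-hydroxy-3-methoxyphenyl for 4-methoxyphenyl, and it bears on the new step only loosely. Only part of that exchange is reversed in compound 3. A modest step toward a lower number, smaller than the measured one, is expected for compound 3 in this assay: a 1.8-fold lower number from compound 2 to compound 3 (0.25 log units; within the scatter). The estimate for compound 3 is 2500 nM, with a range from 900 nM to 7000 nM.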

Compound 3, half-maximal cytotoxic concentration: 560 nM
The estimate for compound 3 lay 4.5-fold (0.65 log units) above the measured number, outside the stated range (below it).
By their numbers in this assay, from the lowest: compounds 3 and 1 (each within the scatter of the next); then compound 2.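

In this assay, methoxy in place of hydrogen on the aromatic carbon ortho to a methoxy group, the change from 4-methoxyphenyl to 3,4-dimethoxyphenyl, gives a 7.9-fold lower number from compound 2 to compound 3 (0.90 log units; beyond the scatter); this isolates a step at this one position, which the earlier exchange of the whole group could not do. Methyl in place of hydrogen on the oxygen on the aromatic ring gives a 1.7-fold lower number from compound 1 to compound 3 (0.23 log units; within the scatter), so hydroxy and methoxy at that place are not told apart in this pair. No measurement on hand accounts for either step.

As far as these compounds go, it remains open whether this position needs an oxygen-linked group at all, or whether an amine, chlorine or a longer chain such as ethoxy would give a similar number. Also open, from the compounds shown here alone, is whether the step holds when the other arm of the shared core is changed.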